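Acetylpiperazine to Piperidine: An Expected Binding Value

The source may hold more compounds than are shown below. What is called first, only, known or untested is meant among the compounds shown, and "the series" means these compounds.

Measured so far in an assay on isolated protein for displacement of a labelled ligand from 5-hydroxytryptamine receptor 6 (Homo sapiens), read by scintillation counting, with a stated time of 1 h; a lower number here means a stronger inhibitor, a higher number a weaker inhibitor:
Compound 1 `O=S(=O)(c1ccccc1)n1ccc2c(O)cccc21` gives 108 nM.
Compound 2 `CC(=O)N1CCN(c2cccc3c2ccn3S(=O)(=O)c2ccccc2)CC1` gives 714 nM.

Among the measured compounds shown here, compound 2 holds the higher of the two numbers, and the only measured step, a 6.6-fold higher number from compound 1 to compound 2 (0.82 log units; beyond the scatter), is what separates it from compound 1. Compound 3 `O=S(=O)(c1ccccc1)n1ccc2c(N3CCCCC3)cccc21` arises from compound 2 by piperidin-1-yl in place of 4-acetylpiperazin-1-yl on an aromatic carbon. No measured step covers this swap; the one step shown concerns a different replacement at the same place and only tells that a larger group there gave a weaker binder than the hydroxy. Compound 3 is therefore expected to stay near compound 2, with an expected step of a 1.8-fold lower number from compound 2 to compound 3 (0.25 log units; within the scatter) and an estimated value of 400 nM (range 120 nM to 1500 nM).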

Compound 3, inhibition constant: 128 nM
Compound 3: the middle estimate sits 3.1-fold (0.49 log units) above what was measured, and the stated range covers the measured number.
By their numbers in this assay, from the lowest: compounds 1 and 3 (each within the scatter of the next); then compound 2.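

Replacing 4-acetylpiperazin-1-yl with piperidin-1-yl gives a 5.6-fold lower number from compound 2 to compound 3 (0.75 log units; beyond the scatter), so a six-membered ring on this aromatic carbon does not in itself bring the weaker binding seen for compound 2. Piperidin-1-yl and hydroxy cannot be told apart here, with a 1.2-fold higher number from compound 1 to compound 3 (0.07 log units; within the scatter). No measurement shown explains the gap between the two rings.

Whether the acetyl group or the second ring nitrogen accounts for that gap stays open. A plain piperazin-1-yl, without the acetyl, would help separate the two.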